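Trimming the Chain on a Weakly Antiproliferative Core

The source may report more compounds than this note shows. Statements on the series, on what has been measured and on what is new or still open speak of the compounds shown alone.

Measured compounds:
compound 1 `CCC(CC)Cn1c(Cc2cc(OC)c(OC)c(OC)c2)nc2c(N)ncnc21`, 158000 nM
compound 2 `C#CCCn1c(Cc2cc(OC)c(OC)c(OC)c2)nc2c(N)nc(F)nc21`, 25100 nM
compound 3 `CC[C@H](C)Cn1c(Cc2cc(OC)c(OC)c(OC)c2)nc2c(N)nc(F)nc21`, 43700 nM

In a functional assay on MCF7 cells (Homo sapiens) for antiproliferative activity (on this read-out higher numbers stand for weaker inhibition and lower numbers for stronger inhibition), compound 1 gives the highest number of the three; compound 3 and compound 2 both sit lower, beyond the scatter. Compound 4 `CCC(C)Cn1c(Cc2cc(OC)c(OC)c(OC)c2)nc2c(N)ncnc21` differs from compound 1 by hydrogen in place of methyl on a saturated chain carbon, three bonds along the chain from an aromatic nitrogen. Going by the values given here, no measured step covers this change. Among the compounds with values here, the only one-place step, a 1.7-fold higher number from compound 2 to compound 3 (0.24 log units; within the scatter), swaps a different chain and stays within the scatter, so it offers little guidance. Within the data shown here, with no direct precedent, a small step at most is expected, and compound 4 is estimated at 120000 nM, between 50000 nM and 300000 nM, a step of a 1.3-fold lower number from compound 1 to compound 4 (0.12 log units; within the scatter) that is not expected to clear the scatter.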

Compound 4, half-maximal inhibitory concentration: 61700 nM
For compound 4 the middle estimate is 1.9-fold (0.29 log units) above the measured one, within the range that was stated.
By their numbers in this assay, from the lowest: compounds 2, 3 and 4 (each within the scatter of the next, the first and the last beyond it); then compound 1.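

In this assay, going from 2-ethylbutyl to 2-methylbutyl gives a 2.6-fold lower number from compound 1 to compound 4 (0.41 log units; beyond the scatter) and so shows that this chain carbon, three bonds along the chain from an aromatic nitrogen, responds to the loss of one methyl. The earlier compounds shown here held no pair that tested this change. Nothing available accounts for the step. From the compounds shown here alone, whether an amine or a longer chain on this carbon would lower or raise the number stays open. So does whether the same change would carry over to the fluorine-bearing compounds.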